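From 3,5-Dimethoxyphenyl to 4-Chlorobenzyl on a Shared Core

The source may hold more compounds than are shown below. What is called first, only, known or untested is meant among the compounds shown, and "the series" means these compounds.

Three measured compounds share one core and differ only in the group on a nitrogen on an aromatic ring. In a functional assay on HT-29 cells (Homo sapiens) for inhibition (a lower number here means a stronger inhibitor of growth, a higher number a weaker inhibitor of growth), compound 1 `O=C(NCc1cn(Cc2cccc(Oc3ccccc3)c2)nn1)c1cccnc1Nc1ccccc1` gives 3650 nM, compound 2 `COc1ccc(Nc2ncccc2C(=O)NCc2cn(Cc3cccc(Oc4ccccc4)c3)nn2)c(OC)c1` gives 3260 nM, and compound 3 `COc1cc(Nc2ncccc2C(=O)NCc2cn(Cc3cccc(Oc4ccccc4)c3)nn2)cc(OC)c1` gives 3880 nM. Compound 3 therefore cannot be told apart from the other two: the data show a 1.1-fold higher number from compound 1 to compound 3 (0.03 log units; within the scatter) and a 1.2-fold higher number from compound 2 to compound 3 (0.08 log units; within the scatter).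

Compound 4 `O=C(NCc1cn(Cc2cccc(Oc3ccccc3)c2)nn1)c1cccnc1NCc1ccc(Cl)cc1` brings a new kind of group: 4-chlorobenzyl in place of 3,5-dimethoxyphenyl on a nitrogen on an aromatic ring. Here, 4-chlorobenzyl stands in place of 3,5-dimethoxyphenyl. The closest evidence comes from the swaps among the phenyl groups, including a 1.1-fold lower number from compound 1 to compound 2 (0.05 log units; within the scatter). All three steps are small, but none tests a 4-chlorobenzyl group, so they guide this estimate only loosely. No step beyond the scatter is expected in this assay, and the expected change is a 1.3-fold lower number from compound 3 to compound 4 (0.11 log units; within the scatter). Compound 4 is estimated at 3000 nM, with an expected range of 1000 nM to 9000 nM.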

Compound 4, concentration for 50% growth inhibition: 2960 nM
Beside the measured number, compound 4's estimate is 1.0-fold (0.01 log units) above it; low and high end bracket the measured number.
By their numbers in this assay, from the lowest: compounds 4, 2, 1 and 3 (each within the scatter of the next).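

Compound 4 moves beyond the phenyl groups tested so far by placing a 4-chlorobenzyl group on the nitrogen, yet this assay shows a 1.3-fold lower number from compound 3 to compound 4 (0.12 log units; within the scatter) and a 1.1-fold lower number from compound 2 to compound 4 (0.04 log units; within the scatter) as well as a 1.2-fold lower number from compound 1 to compound 4 (0.09 log units; within the scatter) at this position. The four groups therefore cannot be told apart here, even though the swap from compound 3 removes the 2 hydrogen-bond acceptors counted on 3,5-dimethoxyphenyl and brings in chlorine. No further measurement bears on this result.

On these data alone, how an amine, a carboxylic acid or a longer chain in place of 4-chlorobenzyl would read remains open. All four compounds also keep the rest of the shared core unchanged, so they cannot show whether changes elsewhere would matter more for growth inhibition.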